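Adding two methoxy groups: from compound 3 to compound 4

A few compounds are considered here, and "the series" means these few. Any claim that something is new, unique, unknown or untested is made for them only; others in the source may bear on it.

Measured compounds:
compound 1 `COc1ccc2nc(NC(=O)c3cc(-c4cc(OC)c(OC)c(OC)c4)n4nc(-c5ccccc5)cc4n3)sc2c1` gives 3980 nM
compound 2 `Cc1cc2nc(NC(=O)c3cc(-c4ccc(F)cc4)n4nc(-c5ccccc5)cc4n3)sc2cc1C` gives 12900 nM
compound 3 `COc1ccc(-c2cc(C(=O)Nc3nc4cc(C)c(C)cc4s3)nc3cc(-c4ccccc4)nn23)cc1` gives 12300 nM

In a functional assay on DU-145 cells (Homo sapiens) for cytotoxicity, read by MTT assay, with a stated time of 48 h (on this read-out lower numbers stand for stronger inhibition and higher numbers for weaker inhibition), compound 3 stands second highest of three numbers, with compound 2 within the scatter and compound 1 the furthest away. Compound 4 `COc1cc(-c2cc(C(=O)Nc3nc4cc(C)c(C)cc4s3)nc3cc(-c4ccccc4)nn23)cc(OC)c1OC` differs from compound 3 in one place: 3,4,5-trimethoxyphenyl in place of 4-methoxyphenyl on an aromatic carbon. For the measured compounds named here, the only one-place step measured, a 1.0-fold lower number from compound 2 to compound 3 (0.02 log units; within the scatter), concerns a different group and does not bear on this change. Compound 1 carries the same 3,4,5-trimethoxyphenyl and gives the lowest number shown, but it differs from compound 3 in another part as well, so it is only a hint. A modest drop is expected, a 2.1-fold lower number from compound 3 to compound 4 (0.31 log units; beyond the scatter), with wide uncertainty. Compound 4 is estimated at 6000 nM, between 2000 nM and 18000 nM.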

Compound 4, half-maximal inhibitory concentration: 3710 nM
Compound 4: the middle estimate sits 1.6-fold (0.21 log units) above what was measured, and the stated range covers the measured number.
By their numbers in this assay, from the lowest: compounds 4 and 1 (each within the scatter of the next); then compounds 3 and 2 (each within the scatter of the next).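

Within this assay this position does respond to its substituents: 3,4,5-trimethoxyphenyl in place of 4-methoxyphenyl gives a 3.3-fold lower number from compound 3 to compound 4 (0.52 log units; beyond the scatter) and in place of 4-fluorophenyl gives a 3.5-fold lower number from compound 2 to compound 4 (0.54 log units; beyond the scatter) whereas methoxy in place of fluoro alone stayed within the scatter. With 3,4,5-trimethoxyphenyl present in both, 5,6-dimethyl-1,3-benzothiazol-2-yl in place of 6-methoxy-1,3-benzothiazol-2-yl gives a 1.1-fold lower number from compound 1 to compound 4 (0.03 log units; within the scatter) so that swap on the amide-type nitrogen shows no real difference.

Nothing available explains the gain from the added methoxy groups. From the compounds shown here alone, whether a single added methoxy, or an amine or a carboxylic acid on this phenyl ring, would act the same way remains open.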